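Ring Size of the Amide Partner in a Cytotoxicity Series

The source may report more compounds than this note shows. Statements on the series, on what has been measured and on what is new or still open speak of the compounds shown alone.

Compound 2 `O=C1C=CC(=O)C(c2cc(-c3ccc(C(=O)N4CCCC4)s3)on2)=C1` carries a pyrrolidin-1-yl group on its amide carbonyl. In a functional assay on A549 cells (Homo sapiens) for cytotoxicity, read by XTT assay, with a stated time of 72 h (on this read-out higher numbers stand for weaker inhibition and lower numbers for stronger inhibition), compound 2 reaches only the limit of the assay, > 30000 nM. Compound 1 `CN(Cc1ccccc1)C(=O)c1ccc(-c2cc(C3=CC(=O)C=CC3=O)no2)s1` likewise reaches only a limit, > 30000 nM. Among the compounds with values here, the single measured step, a step that the two limits leave unreadable from compound 1 to compound 2, therefore has no readable size, and both measured compounds sit at the limit of > 30000 nM in this assay, at which 2 of the 2 values shown sit. Compound 3 `O=C1C=CC(=O)C(c2cc(-c3ccc(C(=O)N4CCCCC4)s3)on2)=C1` differs from compound 2 at the same place: piperidin-1-yl in place of pyrrolidin-1-yl on a carbonyl carbon. Within the data shown here, no measured step bears on this change, so no direction can be read from the numbers. The estimated step is a step that the limit leaves unreadable from compound 2 to compound 3. Compound 3 is thus expected at 40000 nM, within 15000 nM to 100000 nM.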

Compound 3, half-maximal inhibitory concentration: > 30000 nM
Compound 3: a limit, no number; the forecaster's own chance of this, stated with the estimate: 85%; the middle value lies beyond the limit too.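

Within the data shown here, compound 1, compound 2 and compound 3 all stand at a limit, not a number, so no new step between them can be read: the limit of > 30000 nM in this assay, at which 3 of the 3 values shown sit.

Going by these compounds, whether any amide partner on the shared core gives a readable value in this assay stays open.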